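Adding a Piperidinylmethyl Group to Compound 1

The source may report more compounds than this note shows. Statements on the series, on what has been measured and on what is new or still open speak of the compounds shown alone.

Compound 1 `COc1cc(O)c(C(=O)c2cccc(F)c2)c(OC)c1` gives 38% in a functional assay on THP-1 cells (Homo sapiens) for inhibition, read by ELISA, with stated times of 30 min and 24 h, tested at 1 uM (on this read-out lower numbers stand for a weaker effect and higher numbers for a stronger effect at the one concentration tested), the highest of the three numbers measured. Compound 3 `COc1cc(O)c(C(=O)c2cccc(Cl)c2)c(OC)c1`, which carries chloro in place of fluoro on an aromatic carbon, gives 31% in this assay, and the step of a number 7 percentage points lower from compound 1 to compound 3 (within the scatter) lies within the scatter. Compound 2 `COc1cc(OC)c(C(=O)c2ccccc2F)c(O)c1CN1CCCC1` gives 15% in this assay; it differs from compound 1 in more than one place, so only its value can be set beside that of compound 1, and the two lie beyond the scatter of each other.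

Compound 4 `COc1cc(OC)c(C(=O)c2cccc(F)c2)c(O)c1CN1CCCCC1` differs from compound 1 by (piperidin-1-yl)methyl in place of hydrogen on an aromatic carbon. For the measured compounds named here, no measured step covers a single change of this kind, and the one measured step, from compound 1 to compound 3, concerns a halogen and is within the scatter, so it does not bear on this change. Going by the values given here, the only guidance is compound 2, the one measured compound that carries a comparable substituent, whose value in this assay is the lowest of the three. On that basis compound 4 is expected to give about 20%, within 8% to 34%. This corresponds to an expected downward step a number 18 percentage points lower from compound 1 to compound 4 (beyond the scatter), beyond the scatter.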

Compound 4, a percentage reported as activity, at one concentration (the size of the read-out at that concentration, not a potency): 30%
Estimate against measurement, compound 4: 10 percentage points below, and the stated range covers the measured number.
By their numbers in this assay, from the lowest: compound 2; then compounds 4, 3 and 1 (each within the scatter of the next).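

The step of a number 8 percentage points lower from compound 1 to compound 4 (within the scatter) in this assay is the first single change shown on this aromatic carbon, which is ortho to a hydroxy group and ortho and para to methoxy groups. It shows that (piperidin-1-yl)methyl, with its six-membered non-aromatic ring, can enter in place of hydrogen at this position with the read-out staying within the scatter, something the halogen step on the other ring could not show. Nothing among the data shown accounts for this result.

As far as these compounds go, whether a different amine on the same methyl link, such as morpholin-4-ylmethyl or dimethylaminomethyl, or a longer chain carrying the piperidine, would also stay within the scatter remains open. Also open, from the compounds shown here alone, is whether the same holds with chloro in place of fluoro on the core of compound 3.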